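Series notes: methoxy in place of hydrogen, toward compound 4

The compounds below may be only part of what the source reports. "The series", "measured", "known", "first", "only" and "open" are said of these compounds alone.

Of the compounds shown here, three of the shared core have been measured in a functional assay on U-87MG ATCC cells for antiproliferative activity against U-87 MG (Homo sapiens), read by MTT assay, with a stated time of 48 h, tested at 100 uM; on this read-out lower numbers stand for a stronger effect and higher numbers for a weaker effect at the one concentration tested. Compound 1 `COc1ccc(-c2nc(C)c(C(=O)CSc3nc(-c4cccc(OC)c4)c(C#N)c(=O)[nH]3)s2)cc1` gives 12.4% in this assay. Compound 2 `Cc1nc(-c2ccc(Cl)cc2)sc1C(=O)CSc1nc(-c2cccc(Cl)c2)c(C#N)c(=O)[nH]1` gives 12.5% in this assay. Compound 3 `Cc1nc(-c2ccccc2)sc1C(=O)CSc1nc(-c2cccc(Cl)c2)c(C#N)c(=O)[nH]1` gives 10% in this assay, the lowest of the three numbers; its nearest neighbour is compound 1 and its furthest is compound 2, and both gaps lie within the scatter, so no order among the three can be read.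

Going by the values given here, the one step that has been measured, a number 2.5 percentage points lower from compound 2 to compound 3 (within the scatter), concerns a different position and is itself within the scatter. Compound 4 `COc1ccc(-c2nc(C)c(C(=O)CSc3nc(-c4cccc(Cl)c4)c(C#N)c(=O)[nH]3)s2)cc1` carries the change (methoxy in place of hydrogen on an aromatic carbon). Among the compounds with values here, no measured pair shows exactly this change. Compound 1 already carries a methoxy at the same place, and the values of compound 1 and compound 3 stand within the scatter of each other, which gives no sign that the methoxy by itself shifts this read-out.

For compound 4 the step of a number 2 percentage points higher from compound 3 to compound 4 (within the scatter) is therefore expected to stay within the scatter. Compound 4 is estimated to give 12% in this assay, with a range from 4% to 22%.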

Compound 4, a percentage reported as activity, at one concentration (the size of the read-out at that concentration, not a potency): 40.6%
Beside the measured number, compound 4's estimate is 28.6 percentage points below it; measured number above the stated range.
By their numbers in this assay, from the lowest: compounds 3, 1 and 2 (each within the scatter of the next); then compound 4.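

In this assay this position turns out not to be indifferent to substitution: with the chloro on the other aryl ring kept, phenyl to 4-methoxyphenyl gives a number 30.6 percentage points higher from compound 3 to compound 4 (beyond the scatter), and methoxy in place of chloro at the same place gives a number 28.1 percentage points higher from compound 2 to compound 4 (beyond the scatter), so methoxy here stands apart from hydrogen and chloro, which lie within the scatter of each other. The methoxy does not act alone, since with the 4-methoxyphenyl kept, chloro in place of methoxy on the other aryl ring gives a number 28.2 percentage points higher from compound 1 to compound 4 (beyond the scatter), so the weaker effect of compound 4 appears only with this pairing of the two substituents among the compounds shown. Nothing at hand bears on the origin of this shift.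

The compounds shown leave open whether the rise belongs to methoxy alone or extends to other groups at this place, such as hydroxy, ethoxy or dimethylamino. They also leave open how the methoxy would read with hydrogen on the other aryl ring, and a single concentration gives no potency for any of these compounds.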